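A Larger Carbonyl Substituent on Compound 1

A few compounds are considered here, and "the series" means these few. Any claim that something is new, unique, unknown or untested is made for them only; others in the source may bear on it.

Measured so far in a functional assay on MCF7 cells (Homo sapiens) for inhibition, read by MTT assay, with a stated time of 72 h; a higher number here means a weaker inhibitor, a lower number a stronger inhibitor
- compound 1 `CCC(=O)N1CCN(c2nnc3nncn3n2)CC1` gives 14800 nM
- compound 2 `OCCNc1nnc2nncn2n1` gives 11600 nM
- compound 3 `OCC(CO)(CO)Nc1nnc2nncn2n1` gives > 100000 nM as a limit of the assay, not a number

Within the data shown here, compound 1 and compound 2 lie within the usual scatter of each other, so compound 1 stands level with the only other exact number. Compound 4 `CC(C)COC(=O)N1CCN(c2nnc3nncn3n2)CC1` differs from compound 1 by one change, isobutoxy in place of ethyl on a carbonyl carbon. Among the measured compounds shown here, no measured pair isolates this change, so the expectation is loose: a modest step toward a lower number in this assay, possibly none beyond the scatter. The expected change is a 1.6-fold lower number from compound 1 to compound 4 (0.22 log units; within the scatter) as an estimate only. For compound 4 the estimate is 9000 nM with an expected range from 2500 nM to 35000 nM.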

Compound 4, half-maximal inhibitory concentration: 5390 nM
Beside the measured number, compound 4's estimate is 1.7-fold (0.22 log units) above it; the measured number falls inside the stated range.
By their numbers in this assay, from the lowest: compound 4; then compounds 2 and 1 (each within the scatter of the next). At a limit, above all of these: compound 3.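

Among these compounds, compound 4 gives the first reading of what a change on this carbonyl carbon does: in this assay, isobutoxy in place of ethyl gives a 2.7-fold lower number from compound 1 to compound 4 (0.44 log units; beyond the scatter). The position therefore responds to its substituent, and the larger group, with its added oxygen, is accepted without any loss. What lies behind the step cannot be told from the data shown.

From the compounds shown here alone, it remains open whether the oxygen or the branched carbons matter more. Methoxy or isopentyl on the same carbonyl carbon would help separate the two.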